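The source may report more compounds than this note shows. Statements on the series, on what has been measured and on what is new or still open speak of the compounds shown alone.

In a functional assay on A549 cells (Homo sapiens) for cytotoxicity, read by CCK-8 assay (a lower number here means a stronger inhibitor, a higher number a weaker inhibitor), the compounds shown so far all sit at the weak end of the scale. Among the compounds with values here, compound 1 (`COc1ccc(NC(=O)c2ncc(-c3cc(OC)c(OC)c(OC)c3)o2)cc1`) gives 25800 nM, the only true number available. Compound 2 (`O=C(Nc1ccc(O)cc1)c1ncc(-c2ccc(F)cc2)o1`) is reported only as a limit, > 30000 nM. Compound 3 (`Cc1ccc(NC(=O)c2ncc(-c3ccccc3)o2)cc1`) is likewise known only as a limit, > 30000 nM. The picture is thus dominated by the limit of > 30000 nM in this assay, at which 2 of the 3 values shown sit.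

Compound 4 (`O=C(Nc1ccc(Cl)cc1)c1ncc(-c2ccccc2)o1`) differs from compound 3 by a single change, chloro in place of methyl on an aromatic carbon, so that 4-methylphenyl becomes 4-chlorophenyl. Within the data shown here, no measured pair shows the size of such a change in this assay. Among the measured compounds shown here, no large step is expected, and no direction is expected beyond the scatter, since compound 1 at 25800 nM is the only numerical guide. The expected outcome is a number no higher from compound 3 to compound 4 (the limit leaves the size open). Compound 4 may well be reported only as a limit too. Compound 4 is estimated at 30000 nM, with an expected range from 12000 nM to 60000 nM.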

Compound 4, half-maximal inhibitory concentration: > 30000 nM
Compound 4: a limit, no number; the forecaster's own chance of this, stated with the estimate: 60%; the middle value lies on the limit itself.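

Compound 3 and compound 4 are both reported in this assay only as limits, not as numbers, so no step can be read between them. The compounds shown leave open whether exchanging 4-methylphenyl for 4-chlorophenyl changes cytotoxicity at all, and in which direction.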